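The compounds below may be only part of what the source reports. "The series", "measured", "known", "first", "only" and "open" are said of these compounds alone.

Measured in an ADME assay on microsomes from liver (Homo sapiens) for metabolic stability, with a stated time of 10 min, tested at 0.5 uM; on this read-out lower numbers stand for a less stable compound and higher numbers for a more stable compound:
compound 1 `Cc1noc(C)c1[C@@H]1C[C@@](C)(c2ccc(F)cc2F)N=C(N)S1`: 24%
compound 2 `CCc1noc(C)c1[C@@H]1C[C@@](C)(c2ccc(F)cc2F)N=C(N)S1`: 21%
compound 3 `Cc1onc(-c2ccccc2)c1[C@@H]1C[C@@](C)(c2ccc(F)cc2F)N=C(N)S1`: 38%

Compound 1 lies within the scatter of its nearest neighbour, a number 3 percentage points lower from compound 1 to compound 2 (within the scatter). Its furthest neighbour lies beyond the scatter, a number 14 percentage points higher from compound 1 to compound 3 (beyond the scatter).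

Compound 4 `Cc1noc(-c2ccc(F)cc2)c1[C@@H]1C[C@@](C)(c2ccc(F)cc2F)N=C(N)S1` is unmeasured and differs from compound 1 as follows: 4-fluorophenyl in place of methyl on an aromatic carbon. The new group is 4-fluorophenyl in place of methyl, on the aromatic carbon next to the ring oxygen.

Going by the values given here, the closest precedent is a number 14 percentage points higher from compound 1 to compound 3 (beyond the scatter), also an aromatic ring replacing methyl, though on another ring carbon. a number 17 percentage points higher from compound 2 to compound 3 (beyond the scatter) is of similar size. A modest rise is therefore expected, a number 11 percentage points higher from compound 1 to compound 4 (beyond the scatter), with wide uncertainty on this single precedent. The estimate for compound 4 is 35%, with an expected range of 20% to 52%.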

Compound 4, percent of the compound remaining: 45%
Compound 4: middle estimate off by 10 percentage points, on the low side, and the stated range covers the measured number.
By their numbers in this assay, from the lowest: compounds 2 and 1 (each within the scatter of the next); then compounds 3 and 4 (each within the scatter of the next).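

In this assay, 4-fluorophenyl in place of methyl on the aromatic carbon next to the ring oxygen gives a number 21 percentage points higher from compound 1 to compound 4 (beyond the scatter). This carbon therefore accepts a much larger aromatic group without loss of stability, and the earlier rise with phenyl, on another ring carbon, is no longer the only case of its kind. Nothing available explains the step.

Open, as far as these compounds go, is whether the fluorine matters to this step, or whether the six-membered aromatic ring alone accounts for it. From the compounds shown here alone, the response at this carbon to a non-aromatic group, such as a morpholine or a carboxylic acid, also remains open.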